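From Cyclopentyl to Cyclohexyl on a Shared Core

This account rests on a few compounds, and the source may have more. Where it says the series, first, only, none or still open, it means among the compounds named here.

In an ADME assay on Caco-2 cells (Homo sapiens) for permeability, read by LC-MS, with a stated time of 2 h (a higher number here means that the compound crosses the layer faster, a lower number that the compound crosses the layer more slowly), compound 1 `CCCN(Cc1ccc(OCCN2C(=O)CCC2=O)c(C)c1)C(CC(=O)O)c1ccc(Cl)cc1` gives 10.2 nm/s, while compound 2 `Cc1cc(CN(CC2CCCC2)C(CC(=O)O)c2ccc(Cl)cc2)ccc1OCCN1C(=O)CCC1=O` gives 28.9 nm/s, the higher of the two numbers. Compound 3 `Cc1cc(CN(CC2CCCCC2)C(CC(=O)O)c2ccc(Cl)cc2)ccc1OCCN1C(=O)CCC1=O` has not yet been measured. Its difference from compound 2 is cyclohexyl in place of cyclopentyl on a saturated chain carbon bound to an amine nitrogen, which puts cyclohexyl in place of cyclopentyl on a saturated chain carbon bound to an amine nitrogen. For the measured compounds named here, only one measured step bears on this change: a 2.8-fold higher number from compound 1 to compound 2 (0.45 log units; beyond the scatter), a modest rise beyond the scatter, where cyclopentyl replaced ethyl at the same place. Going by the values given here, that step started from ethyl, and no measured pair compares two ring sizes, so it offers only a weak guide to direction. The expected step is a 1.1-fold higher number from compound 2 to compound 3 (0.06 log units; within the scatter), a small rise that probably stays within the scatter. For compound 3 the estimate is 33 nm/s, with an expected range from 16 nm/s to 65 nm/s.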

Compound 3, apparent permeability: 83.9 nm/s
Estimate against measurement, compound 3: 2.5-fold (0.41 log units) below, and the stated range ends below it.
By their numbers in this assay, from the lowest: compound 1; then compound 2; then compound 3.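

In this assay, for the compounds shown here, the size of the ring on a saturated chain carbon bound to an amine nitrogen proves to matter: cyclohexyl in place of cyclopentyl gives a 2.9-fold higher number from compound 2 to compound 3 (0.46 log units; beyond the scatter) and so moves the number beyond the scatter, where no earlier pair had compared two ring sizes. Across the three compounds the number rises in the order ethyl, cyclopentyl, cyclohexyl, with no compound shown going against that order, and the full span is an 8.2-fold higher number from compound 1 to compound 3 (0.92 log units; beyond the scatter) at this one place on the shared core. Nothing available here accounts for the size of these steps.

The compounds shown leave open whether the rise continues with cycloheptyl or ends at cyclohexyl. They also leave open whether an open carbon chain, a phenyl ring or a tetrahydropyranyl ring would follow the same order.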